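Ethoxy replaces methylpiperazinyl on the benzothiazole-type amide carbonyl

The compounds below may be only part of what the source reports. "The series", "measured", "known", "first", "only" and "open" are said of these compounds alone.

Of the compounds shown here, two have been measured in an ADME assay on RAW264.7 cells (Mus musculus) for cytotoxicity, read by MTT assay, with a stated time of 72 h, tested at 50 ug/mL; a lower number here means less inhibition, a higher number more inhibition at the concentration tested (going by the name of the read-out). Compound 1 `CCOC(=O)c1nc2cc(Cl)ccc2s1` gives 37.4% in this assay. Compound 2 `CN1CCN(C(=O)c2nc3cc(C(F)(F)F)ccc3s2)CC1` gives 12.6% in this assay, the lower of the two numbers, and the gap to compound 1 lies beyond the scatter of this assay. Within the data shown here, no pair of measured compounds differs in a single place, so no measured step is available.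

Compound 3 `CCOC(=O)c1nc2cc(C(F)(F)F)ccc2s1` has not been measured. It differs from compound 2 in one place: ethoxy in place of 4-methylpiperazin-1-yl on a carbonyl carbon. The expectation for compound 3 rests on compound 1, which also carries an ethoxy on its carbonyl carbon and gives 37.4%. The step from compound 2 to compound 3 is therefore expected to be upward and beyond the scatter, about a number 20.4 percentage points higher from compound 2 to compound 3 (beyond the scatter). Compound 3 is estimated to give 33% in this assay, within a range from 15% to 50%.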

Compound 3, a percentage reported as inhibition, at one concentration (the size of the read-out at that concentration, not a potency): 29.1%
Compound 3: the middle estimate sits 3.9 percentage points above what was measured; the measured number falls inside the stated range.
By their numbers in this assay, from the lowest: compound 2; then compounds 3 and 1 (each within the scatter of the next).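

In this assay, ethoxy in place of 4-methylpiperazin-1-yl on the carbonyl carbon gives a number 16.5 percentage points higher from compound 2 to compound 3 (beyond the scatter), with trifluoromethyl kept on the aromatic carbon. This isolates the group on the carbonyl carbon as a change that moves the read-out at this concentration. With ethoxy on the carbonyl carbon, trifluoromethyl in place of chloro on the aromatic carbon gives a number 8.3 percentage points lower from compound 1 to compound 3 (within the scatter), so this exchange does not separate the two ethoxy compounds in this assay.

As far as these compounds go, it remains open whether a simple dimethylamine amide, a morpholine amide or the free carboxylic acid on the carbonyl carbon would read like compound 2 or like compound 3. From the compounds shown here alone, it is also open whether chloro and trifluoromethyl would still read alike with 4-methylpiperazin-1-yl on the carbonyl carbon. No independent measurement bears on what lies behind these steps.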